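Changing the Aryl Group on the Amide of Compound 2

The source may report more compounds than this note shows. Statements on the series, on what has been measured and on what is new or still open speak of the compounds shown alone.

Measured so far in a functional assay on SF-539 cells (Homo sapiens) for inhibition, read by sulforhodamine B assay, with a stated time of 48 h, tested at 10 uM; a higher number here means a weaker effect of the compound at the concentration tested, a lower number a stronger effect:
compound 1, `COc1cc(Cl)cc(-c2nn(-c3cccc(NC(=O)Nc4ccc(Cl)c(C(F)(F)F)c4)c3)cc2-c2ccncc2)c1`, gives -1.17%
compound 2, `COc1cc(Cl)cc(-c2nn(-c3cccc(NC(=O)c4ccc(Cl)c(Cl)c4)c3)cc2-c2ccncc2)c1`, gives 74.5%

Among the measured compounds shown here, compound 2 stands highest of the two numbers in this assay; its nearest neighbour is compound 1, and the only measured step, a number 75.7 percentage points higher from compound 1 to compound 2 (beyond the scatter), runs in the direction of a weaker effect for compound 2.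

The next compound, compound 3, `COc1cc(Cl)cc(-c2nn(-c3cccc(NC(=O)c4cccc(C(F)(F)F)c4)c3)cc2-c2ccncc2)c1`, differs from compound 2 in one place: 3-(trifluoromethyl)phenyl in place of 3,4-dichlorophenyl on a carbonyl carbon. The change keeps the amide and exchanges only the aromatic group on the carbonyl carbon.

For the measured compounds named here, the one step on record, a number 75.7 percentage points higher from compound 1 to compound 2 (beyond the scatter), replaced an amino-linked aryl with a directly attached aryl and so changed a different part of the molecule; it says little about swapping one substituted phenyl for another on the same amide. Going by the values given here, no measured pair matches the present change, so the expectation rests on the starting point alone. A step close to the scatter is expected, a number 2.5 percentage points lower from compound 2 to compound 3 (within the scatter), with wide uncertainty in both directions. Compound 3 is therefore estimated at 72% in this assay, within a range of 45% to 100%.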

Compound 3, a percentage reported as activity, at one concentration (the size of the read-out at that concentration, not a potency): 64.2%
For compound 3 the middle estimate is 7.8 percentage points above the measured one; low and high end bracket the measured number.
By their numbers in this assay, from the lowest: compound 1; then compound 3; then compound 2.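

On the aromatic group of the amide, the choice of substituted phenyl does register in this assay: 3-(trifluoromethyl)phenyl in place of 3,4-dichlorophenyl on the carbonyl carbon brings a number 10.3 percentage points lower from compound 2 to compound 3 (beyond the scatter), a modest move towards a stronger effect. That move is small beside a number 65.4 percentage points higher from compound 1 to compound 3 (beyond the scatter), so this amide with a trifluoromethyl group remains far weaker at the tested concentration than compound 1, which carries (4-chloro-3-(trifluoromethyl)phenyl)amino on the carbonyl carbon. No measurement at hand accounts for the size of either step.

With only one exchange of this kind, the compounds shown cannot separate the loss of the two chlorine atoms from the arrival of the trifluoromethyl group, since both happen in the same step. Also open, on these data alone, is how the read-out would respond to a carboxylic acid or a dimethylamino group on this phenyl ring, or to a longer chain linking the ring to the carbonyl carbon.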